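Hydroxy for nitro on the aryl ring: expected cytotoxicity

This account rests on a few compounds, and the source may have more. Where it says the series, first, only, none or still open, it means among the compounds named here.

Compound 2 `COc1cc(N2C(N)=C(C#N)C(c3ccc([N+](=O)[O-])cc3)C3=C2CC(C)(C)CC3=O)cc(OC)c1OC` gives 25000 nM in a functional assay on Ehrlich cells (Mus musculus) for cytotoxicity; on this read-out lower numbers stand for stronger inhibition and higher numbers for weaker inhibition. Compound 1 `COc1ccccc1C1C(C#N)=C(N)N(c2cc(OC)c(OC)c(OC)c2)C2=C1C(=O)CC(C)(C)C2` gives 26600 nM, so compound 2 and compound 1 lie within the scatter of each other, and no ranking follows. Among the compounds with values here, the only measured step, a 1.1-fold lower number from compound 1 to compound 2 (0.03 log units; within the scatter), exchanged the aryl group on the same saturated ring carbon without moving the number. Compound 3 `COc1cc(N2C(N)=C(C#N)C(c3ccc(O)cc3)C3=C2CC(C)(C)CC3=O)cc(OC)c1OC` carries the change (hydroxy in place of nitro on an aromatic carbon), again a substituent exchange on that aryl ring. Because a 1.1-fold lower number from compound 1 to compound 2 (0.03 log units; within the scatter) stayed flat, no step beyond the scatter is expected; the expected step is no change at the digits printed from compound 2 to compound 3 (within the scatter). Compound 3 is estimated at 25000 nM, range 10000 nM to 60000 nM.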

Compound 3, half-maximal inhibitory concentration: 75800 nM
The estimate for compound 3 lay 3.0-fold (0.48 log units) below the measured number; measured number above the stated range.
By their numbers in this assay, from the lowest: compounds 2 and 1 (each within the scatter of the next); then compound 3.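

In this assay, the substituent on this aryl ring now moves the number: hydroxy in place of nitro gives a 3.0-fold higher number from compound 2 to compound 3 (0.48 log units; beyond the scatter), whereas the earlier aryl exchange stayed within the scatter. The 4-hydroxyphenyl group also separates from 2-methoxyphenyl, with a 2.8-fold higher number from compound 1 to compound 3 (0.45 log units; beyond the scatter), so compound 3 sits apart from both earlier compounds. No available evidence bears on this shift.

Still open, as far as these compounds go, is whether an amine or a carboxylic acid on the same aromatic carbon would track with hydroxy or with nitro. A methoxy group there would test whether the hydroxy hydrogen matters.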